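The compounds below may be only part of what the source reports. "The series", "measured", "known", "first", "only" and "open" are said of these compounds alone.

Measured so far in an ADME assay on the whole organism (Mus musculus, strain BALB/c), at a dose of 30 mg/kg by the oral route; on this read-out higher numbers stand for higher exposure at the dose given and lower numbers for lower exposure:

compound 1, `CC(C)c1ccc(-c2nc(CN3CCN(c4ccnc5cc(-c6cccnc6)ccc45)CC3)no2)cc1`: 11900 ng.h/mL
compound 2, `Cc1cccc(-c2nc(CN3CCN(c4ccnc5cc(-c6cccnc6)ccc45)CC3)no2)c1C`: 8290 ng.h/mL

Compound 2 holds the lower of the two numbers in this assay, but its nearest neighbour is compound 1, and the step of a 1.4-fold lower number from compound 1 to compound 2 (0.16 log units; within the scatter) sits within the scatter, so the two are not separated on this read-out. That single step swaps one six-membered aromatic ring of carbon only for another bearing a different pattern of small carbon groups.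

Compound 3 is `c1cncc(-c2ccc3c(N4CCN(Cc5noc(C6CCCC6)n5)CC4)ccnc3c2)c1`. Relative to compound 2 the change is cyclopentyl in place of 2,3-dimethylphenyl on an aromatic carbon; the group that leaves is a six-membered aromatic ring of carbon only, the group that enters a five-membered non-aromatic ring of carbon only, with the same count of donors and acceptors. Among the measured compounds shown here, the one measured step, from compound 1 to compound 2, bears on the change only in that it also alters the group at this place, and it moved nothing beyond the scatter. For the measured compounds named here, no measured step swaps an aromatic ring for a non-aromatic one here, so no direction is supported; the expectation is a step of a 1.2-fold lower number from compound 2 to compound 3 (0.07 log units; within the scatter) that stays within the scatter. For compound 3 the estimate is 7000 ng.h/mL, with a range from 2500 ng.h/mL to 20000 ng.h/mL.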

Compound 3, area under the concentration-time curve: 20000 ng.h/mL
Beside the measured number, compound 3's estimate is 2.9-fold (0.46 log units) below it, within the range that was stated.
By their numbers in this assay, from the lowest: compounds 2, 1 and 3 (each within the scatter of the next, the first and the last beyond it).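

In this assay, the group on the aromatic carbon of the five-membered aromatic ring need not be an aromatic ring to keep exposure: cyclopentyl in place of 2,3-dimethylphenyl gives a 2.4-fold higher number from compound 2 to compound 3 (0.38 log units; beyond the scatter), a modest change and the only step among these compounds beyond the scatter. Cyclopentyl in place of 4-isopropylphenyl gives a 1.7-fold higher number from compound 1 to compound 3 (0.23 log units; within the scatter), which stays within the scatter, so the difference holds against 2,3-dimethylphenyl alone, and compound 1 and compound 3 are not separated on this read-out. Nothing at hand bears on the reason for either step.

Open, on these data alone, is whether cyclopentyl is a special case among non-aromatic rings, or whether cyclopropyl or cyclohexyl at this place would stand with compound 3 or with compound 2. Also open, as far as these compounds go, is whether an open-chain group such as tert-butyl, or a group carrying an amine such as piperidinyl, would hold exposure at the level of compound 3 on the same core.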